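The compounds below may be only part of what the source reports. "The series", "measured", "known", "first", "only" and "open" are said of these compounds alone.

In a functional assay on HeLa cells (Homo sapiens) for antiproliferative activity, with a stated time of 24 h (a higher number here means a weaker inhibitor, a lower number a stronger inhibitor), compound 1 `NC(=O)c1c(NC(=O)c2ccccc2C(F)(F)F)sc2c1CCN(C(=S)Nc1ccccc1Cl)C2` gives 46900 nM and compound 2 `CSc1ccccc1C(=O)Nc1sc2c(c1C(N)=O)CCN(C(=S)Nc1ccccc1Cl)C2` gives 34700 nM. For the measured compounds named here, compound 2 holds the lower of these two numbers, but the only measured step, a 1.4-fold lower number from compound 1 to compound 2 (0.13 log units; within the scatter), is within the scatter. Compound 3 `NC(=O)c1c(NC(=O)c2ccc(C(F)(F)F)cc2)sc2c1CCN(C(=S)Nc1ccccc1Cl)C2` differs from compound 2 by 4-(trifluoromethyl)phenyl in place of 2-(methylsulfanyl)phenyl on a carbonyl carbon. The step that bears on this exchange is a 1.4-fold lower number from compound 1 to compound 2 (0.13 log units; within the scatter); it covers only part of the present change, and nothing measured argues for a shift beyond the scatter. Compound 3 is therefore expected to show a 1.2-fold higher number from compound 2 to compound 3 (0.06 log units; within the scatter) in this assay. For compound 3 the estimate is 40000 nM, with a range from 14000 nM to 115000 nM.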

Compound 3, half-maximal inhibitory concentration: 44000 nM
Beside the measured number, compound 3's estimate is 1.1-fold (0.04 log units) below it, within the range that was stated.
By their numbers in this assay, from the lowest: compounds 2, 3 and 1 (each within the scatter of the next).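

At the group on the carbonyl carbon, this assay now gives two further readings: 4-(trifluoromethyl)phenyl in place of 2-(methylsulfanyl)phenyl gives a 1.3-fold higher number from compound 2 to compound 3 (0.10 log units; within the scatter), and 4-(trifluoromethyl)phenyl in place of 2-(trifluoromethyl)phenyl gives a 1.1-fold lower number from compound 1 to compound 3 (0.03 log units; within the scatter). Both steps lie within the scatter, so moving the trifluoromethyl from the 2-substituted to the 4-substituted phenyl, a change the earlier pair did not cover, shows no measurable shift here. No data on why these numbers stay so close are available. On these data alone, whether an amine or a carboxylic acid on this phenyl ring would move the number beyond the scatter remains open.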